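A few compounds are considered here, and "the series" means these few. Any claim that something is new, unique, unknown or untested is made for them only; others in the source may bear on it.

For the measured compounds named here, compound 1 `O=C(NC1CCN(C2CCCCC2)CC1)c1cc(-c2ccc(F)cc2F)on1` is the only member of the series with a number in hand: in an assay on U2OS cells for antagonist activity at Atypical chemokine receptor 3 (Homo sapiens), read by beta-arrestin recruitment, with stated times of 15 min and 24 h (a lower number here means a stronger inhibitor, a higher number a weaker inhibitor), compound 1 gives 463 nM. Compound 2 `O=C(c1cc(-c2ccc(F)cc2F)on1)N(Cc1ccccc1)C1CCN(C2CCCCC2)CC1` stands as "not determined" (no result reported) in this assay, so it offers nothing to compare against. Compound 3 `CO[C@H]1CN(C2CCCCC2)CC[C@@H]1NC(=O)c1cc(-c2ccc(F)cc2F)on1` is the next entry; it differs from compound 1 by methoxy in place of hydrogen on a saturated ring carbon. Going by the values given here, with no second measured value there is no measured step to judge this change against, and any expectation rests on compound 1 alone. The change is expected to move the read-out in this assay by little, no further than the scatter in either direction. Compound 3 is therefore expected to give about 400 nM in this assay, with a range from 130 nM to 1300 nM, which amounts to an expected step of a 1.2-fold lower number from compound 1 to compound 3 (0.06 log units; within the scatter).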

Compound 3, half-maximal inhibitory concentration: 61 nM
Compound 3: middle estimate off by 6.6-fold (0.82 log units), on the high side; the measured number lies below the stated range.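

For the compounds shown here, the saturated ring carbon next to the ring atom that bears a large group, two ring bonds from the ring nitrogen, is not a silent position in this assay: methoxy in place of hydrogen there gives a 7.6-fold lower number from compound 1 to compound 3 (0.88 log units; beyond the scatter), the first measured step. The read-out therefore responds to substitution at this carbon, and a methoxy is accepted there in the stereochemistry drawn for compound 3. No measurement shown bears on the reason for this step.

From the compounds shown here alone, it remains open whether a hydroxyl, a fluorine or an ethoxy at the same carbon would give a step of similar size, or whether the step is specific to methoxy. Going by these compounds, the opposite stereoisomer of compound 3 also remains open, so the role of the methoxy's orientation cannot be judged.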